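Compound 1 to compound 4: exchanging the pyridinyl group

The source may report more compounds than this note shows. Statements on the series, on what has been measured and on what is new or still open speak of the compounds shown alone.

Three compounds of the series have numbers in an ADME assay on microsomes from liver (Homo sapiens) for metabolic stability (on this read-out lower numbers stand for slow clearance and higher numbers for fast clearance), so far. Compound 1 `CCn1cnc2c(-c3ccc(F)c(-c4cccnc4)c3)cnnc21` gives 78 mL.min-1.g-1 on this read-out. Compound 2 `CCn1cnc2c(-c3ccc(F)c(Oc4cccc(S(=O)(=O)CC)c4)c3)cnnc21` gives 127 mL.min-1.g-1 and so lies within the scatter of compound 1. Compound 3 `N#Cc1ccc(Oc2cc(-c3cnnc4c3ncn4C3CC3)ccc2F)nc1` gives 17 mL.min-1.g-1 and stands beyond the scatter on the lower side of compound 1. Compound 1 therefore sits with compound 2 at the higher end of the three numbers, well clear of compound 3.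

Compound 4 `CCn1cnc2c(-c3ccc(F)c(-c4ccnc(C)c4)c3)cnnc21` carries 2-methylpyridin-4-yl in place of pyridin-3-yl on an aromatic carbon, ortho to a fluoro group 2-methylpyridin-4-yl in place of pyridin-3-yl on an aromatic carbon and otherwise matches compound 1. For the measured compounds named here, no measured pair differs in one place only, so the data give no direct measure of such an exchange. The estimate therefore starts from compound 1 at 78 mL.min-1.g-1 and, in this assay, no change beyond the scatter is expected, with no firm direction. The expected step runs a 1.1-fold lower number from compound 1 to compound 4 (0.05 log units; within the scatter) and stays within the scatter. Compound 4 is estimated at 70 mL.min-1.g-1 with an expected range from 33 mL.min-1.g-1 to 140 mL.min-1.g-1 on the same read-out.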

Compound 4, intrinsic clearance in microsomes: 157 mL.min-1.g-1
Compound 4: middle estimate off by 2.2-fold (0.35 log units), on the low side; measured number above the stated range.
By their numbers in this assay, from the lowest: compound 3; then compounds 1, 2 and 4 (each within the scatter of the next).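

In this assay, for the compounds shown here, the exchange of pyridin-3-yl for 2-methylpyridin-4-yl supplies the first step that differs in one place only, and it reads as a 2.0-fold higher number from compound 1 to compound 4 (0.30 log units; within the scatter) and thus gives a direct reading at this aromatic carbon, ortho to a fluoro group. The step stays within the scatter, so this pair shows no clear effect of the exchange on clearance, and a single pair cannot divide it between the added methyl and the change of pyridine attachment from the 3-yl to the 4-yl form. No information is at hand that explains the size of the step.

Open, from the compounds shown here alone, is how a plain pyridin-4-yl, a 2-methylpyridin-3-yl or a carboxylic acid at this place would read against compound 1 in this assay on the same shared core, and such compounds could separate the methyl from the attachment. Also open, going by these compounds, is whether the same exchange would give a comparable step with cyclopropyl in place of the ethyl group on the core of compound 1.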